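Swapping the aryl group for tert-butyl: toxicity outlook

The source may hold more compounds than are shown below. What is called first, only, known or untested is meant among the compounds shown, and "the series" means these compounds.

Among the three compounds measured in an ADME assay on Huh-7 cells (Homo sapiens) for cytotoxicity (on this read-out lower numbers stand for higher toxicity in this test and higher numbers for lower toxicity in this test), compound 3 `CN1CCN(CCNCc2cn(-c3ccc(F)cc3F)nc2-c2cccc(Cl)c2)CC1` is the only one that yields a number at all; in this assay compound 3 gives 15000 nM. Compound 1 `Cc1ccccc1CNc1nn(-c2ccc(F)cc2F)cc1CNCCN1CCN(C)CC1` stops at a limit of the test, > 20000 nM. Compound 2 `CN1CCN(CCNCc2cn(-c3ccc(F)cc3F)nc2-c2ccc(S(=O)(=O)N(C)C)cc2)CC1` likewise sits at a limit, > 20000 nM. Two of the three values thus rest at a limit (the limit of > 20000 nM in this assay, at which 2 of the 3 values shown sit), and the two steps that reach compound 3, an at least 1.3-fold lower number from compound 1 to compound 3 (0.12 log units; that floor lies within the scatter) and an at least 1.3-fold lower number from compound 2 to compound 3 (0.12 log units; that floor lies within the scatter), are readable only as floors that the usual scatter covers.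

Compound 4 `CN1CCN(CCNCc2cn(-c3ccc(F)cc3F)nc2C(C)(C)C)CC1` differs from compound 3 by tert-butyl in place of 3-chlorophenyl on an aromatic carbon. The two measured exchanges at this same aromatic carbon, from compound 1 and from compound 2, moved the number in this assay by no readable amount beyond the scatter, so there is no basis for expecting a large shift in either direction here; the likeliest outcome is that compound 4 lands near compound 3 or returns to the limit.

Compound 4 is therefore estimated at 20000 nM, with a range from 9000 nM to 40000 nM. This corresponds to an expected step of a 1.3-fold higher number from compound 3 to compound 4 (0.12 log units; within the scatter), which stays within the scatter.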

Compound 4, half-maximal cytotoxic concentration: > 20000 nM
Compound 4 gave a limit, no number; the forecaster's own chance of this, stated with the estimate: 55%; the middle value lies on the limit itself.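

In this assay, replacing 3-chlorophenyl with tert-butyl takes the ring off this aromatic carbon and leaves 4 heavy atoms in the group instead of 7, and the result is an at least 1.3-fold higher number from compound 3 to compound 4 (0.12 log units; that floor lies within the scatter). This is the first group without a ring shown at this position, and it ends at the same limit as the (2-methylbenzyl)amino group of compound 1 and the 4-(dimethylsulfamoyl)phenyl group of compound 2, so the steps from those two compounds to compound 4 cannot be read. Compound 3 remains the only compound with a number, yet its step to compound 4 has a floor within the usual scatter, so the series does not set compound 3 apart and most of the position's readout rests at one boundary: the limit of > 20000 nM in this assay, at which 3 of the 4 values shown sit.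

On these data alone, how far compounds 1, 2 and 4 lie from that limit stays open, as does whether a primary amine, a carboxylic acid or a longer chain such as n-hexyl on this aromatic carbon would give a number at all. All four compounds also carry the 2,4-difluorophenyl group, so what another group in its place would do is equally unknown.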